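A few compounds are considered here, and "the series" means these few. Any claim that something is new, unique, unknown or untested is made for them only; others in the source may bear on it.

Compound 1 `Nc1ccc2c(c1)/C(=C1\C(=O)Nc3ccccc31)C(=O)N2` — > 25000 nM
Compound 2 `O=C1Nc2cc([N+](=O)[O-])ccc2/C1=C1/Nc2ccccc2C1=O` — > 25000 nM

In an ADME assay on cells (Fibroblast, Homo sapiens) for antiproliferative activity, with a stated time of 72 h (a lower number here means a stronger inhibitor, a higher number a weaker inhibitor), compound 1 gives > 25000 nM, a limit of the assay rather than a number. Compound 2 likewise gives > 25000 nM, also a limit. Compound 1 thus stands at the limit of > 25000 nM in this assay, at which 2 of the 2 values shown sit; the two limits give no ordering. Compound 3 `O=C1Nc2ccccc2/C1=C1\C(=O)Nc2ccc([N+](=O)[O-])cc21` differs from compound 1 by nitro in place of amino on an aromatic carbon. For the measured compounds named here, no measured step covers this change. Because compound 1 sits at the limit of > 25000 nM in this assay, at which 2 of the 2 values shown sit, compound 3 is expected to remain at that limit, so the step that the limit leaves unreadable from compound 1 to compound 3 is expected to be none beyond the scatter. Compound 3 is estimated at 30000 nM, range 10000 nM to 100000 nM.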

Compound 3, half-maximal inhibitory concentration: > 25000 nM
Compound 3 ended at the assay's limit; the forecaster's own chance of this, stated with the estimate: 85%; the middle value does not contradict the limit.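

No step can be read from compound 1 to compound 3 in this assay, since both stand at a limit of the assay: the limit of > 25000 nM in this assay, at which 3 of the 3 values shown sit.

The compounds shown leave open how amino and nitro rank against each other, and what on the shared core would bring a value inside the assay's range.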